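This account rests on a few compounds, and the source may have more. Where it says the series, first, only, none or still open, it means among the compounds named here.

Working notes on the ester series. Compound 1 `CCCOC(=O)C1=C(C)NC(C)=C(C(=O)OC)C1c1csc(-c2ccc(Cl)cc2)n1` gives 5920 nM in an assay on isolated protein for antagonist activity at Voltage-dependent L-type calcium channel subunit alpha-1C (Cavia porcellus), with a stated time of 15 min; on this read-out lower numbers stand for stronger inhibition and higher numbers for weaker inhibition. Compound 2 `COC(=O)C1=C(C)NC(C)=C(C(=O)OC(C)(C)C)C1c1csc(-c2ccc(Cl)cc2)n1` gives 46000 nM; compound 3 `COC(=O)C1=C(C)NC(C)=C(C(=O)OCc2ccccc2)C1c1csc(-c2ccc(Cl)cc2)n1` gives 64900 nM, the highest of the three numbers, though the step between these two is a 1.4-fold higher number from compound 2 to compound 3 (0.15 log units; within the scatter). The larger ester changes were a 7.8-fold higher number from compound 1 to compound 2 (0.89 log units; beyond the scatter) and an 11-fold higher number from compound 1 to compound 3 (1.04 log units; beyond the scatter). Compound 4 `COC(=O)C1=C(C)NC(C)=C(C(=O)OCCc2ccccc2)C1c1csc(-c2ccc(Cl)cc2)n1` differs from compound 3 by benzyl in place of phenyl on a saturated chain carbon bound to an oxygen next to a carbonyl group. For the measured compounds named here, no measured step covers this exact extension; the two steps that end at compound 3, from compound 2 and from compound 1, suggest that adding one more chain carbon to the benzyl ester would move the number little, if at all beyond the scatter, in this assay. Compound 4 is therefore expected at about 60000 nM (range 25000 nM to 150000 nM), a step of a 1.1-fold lower number from compound 3 to compound 4 (0.03 log units; within the scatter).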

Compound 4, half-maximal inhibitory concentration: 10200 nM
Estimate against measurement, compound 4: 5.9-fold (0.77 log units) above; measured number outside the range, below it.
By their numbers in this assay, from the lowest: compounds 1 and 4 (each within the scatter of the next); then compounds 2 and 3 (each within the scatter of the next).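

Lengthening the ester chain by one carbon is not a silent change at this position: phenethyl in place of benzyl gives a 6.4-fold lower number from compound 3 to compound 4 (0.80 log units; beyond the scatter) and so restores much of what the bulkier esters lost. The phenethyl ester also separates from the tert-butyl ester, with a 4.5-fold lower number from compound 2 to compound 4 (0.65 log units; beyond the scatter), whereas a 1.7-fold higher number from compound 1 to compound 4 (0.24 log units; within the scatter) leaves it level with the propyl ester. No measurement at hand gives a reason for this chain-length effect. Still open, as far as these compounds go, is whether a longer chain, such as phenylpropyl, holds this level, and whether an amine on the chain is tolerated.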